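The source may report more compounds than this note shows. Statements on the series, on what has been measured and on what is new or still open speak of the compounds shown alone.

In a functional assay on U-87MG ATCC cells (Homo sapiens) for cytotoxicity, read by MTT assay, with a stated time of 72 h (on this read-out higher numbers stand for weaker inhibition and lower numbers for stronger inhibition), compound 1 `COc1ccc(/C=N/NC(=O)Nc2ccc(Oc3ccnc(-c4nncn4CCN(C)C)c3)c(F)c2)c(OC)c1OC` gives 7650 nM, the higher of the two numbers recorded, and compound 3 `CN(C)CCn1cnnc1-c1cc(Oc2ccc(NC(=O)N/N=C/c3ccc(F)cc3F)cc2F)ccn1` gives 1900 nM. Compound 2 `Cn1ncnc1-c1cc(Oc2ccc(NC(=O)N/N=C/c3ccccc3)cc2F)ccn1` reaches only a limit of this assay, > 100000 nM. Among the measured compounds shown here, the one measured step that changes the ring on the carbon with a double bond to nitrogen is a 4.0-fold lower number from compound 1 to compound 3 (0.60 log units; beyond the scatter). Compound 4 `CN(C)CCn1cnnc1-c1cc(Oc2ccc(NC(=O)N/N=C/c3ccc(O)c(O)c3)cc2F)ccn1` alters the same place: 3,4-dihydroxyphenyl in place of 2,3,4-trimethoxyphenyl on a carbon with a double bond to nitrogen. For the measured compounds named here, no measured pair shows what two hydroxyl groups on that ring do, so the step from compound 1 is expected to be small, most likely toward a lower number, as a 1.5-fold lower number from compound 1 to compound 4 (0.18 log units; within the scatter). Compound 4 is therefore estimated at 5000 nM, within a range from 1500 nM to 20000 nM.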

Compound 4, half-maximal inhibitory concentration: > 100000 nM
Compound 4: a limit, no number; the forecaster's own chance of this, stated with the estimate: 10%; middle value at least 20-fold (1.30 log units) from the limit.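

Putting 3,4-dihydroxyphenyl on this carbon gives an at least 13-fold higher number from compound 1 to compound 4 (1.11 log units; beyond the scatter) and an at least 52-fold higher number from compound 3 to compound 4 (1.72 log units; beyond the scatter). The ring at this position can therefore move the read-out much further than the earlier step between compound 1 and compound 3 showed. The result for compound 4 is a limit, not a number: the limit of > 100000 nM in this assay, at which 2 of the 4 values shown sit.

As far as these compounds go, it remains open whether the step follows from the two hydroxyl groups themselves or from the loss of the methoxy groups. A phenyl ring with a single hydroxyl group, or with an amino group, at this position would help to separate the two.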